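Replacing the Halogenated Aryl Amide in Compound 2

A few compounds are considered here, and "the series" means these few. Any claim that something is new, unique, unknown or untested is made for them only; others in the source may bear on it.

Measured so far:
compound 1 `O=C(CN1CCN(c2nnc(Cc3ccccc3)c3ccccc23)CC1)Nc1ccc(F)c(F)c1` — 9510 nM
compound 2 `O=C(CN1CCN(c2nnc(Cc3ccccc3)c3ccccc23)CC1)Nc1ccc(F)c(Cl)c1` — 13300 nM

Both compounds were tested in a functional assay on HT-29 cells (Homo sapiens) for cytotoxicity, read by MTT assay, with a stated time of 72 h; on this read-out lower numbers stand for stronger inhibition and higher numbers for weaker inhibition. Among the measured compounds shown here, compound 2 gives the higher of the two numbers, with compound 1 its only neighbour, but the step of a 1.4-fold higher number from compound 1 to compound 2 (0.15 log units; within the scatter) lies within the scatter, so the two cannot be told apart on these measurements.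

Compound 3 `Cc1ccccc1NC(=O)CN1CCN(c2nnc(Cc3ccccc3)c3ccccc23)CC1` differs from compound 2 in a single place: 2-methylphenyl in place of 3-chloro-4-fluorophenyl on an amide-type nitrogen. For the measured compounds named here, the one measured step, a 1.4-fold higher number from compound 1 to compound 2 (0.15 log units; within the scatter), alters the same ring, but only by exchanging one halogen for another, and it produced no change beyond the scatter. Going by the values given here, the step to compound 3 is broader: both halogens leave and a methyl group enters, and no measured pair shows such an exchange. Among the compounds with values here, the single relevant step therefore gives little reason to expect a move in either direction, and a step within the scatter is the most reasonable expectation, with a wide range to reflect the lack of direct precedent.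

Compound 3 is therefore expected to give about 11000 nM in this assay, with an estimated range from 3000 nM to 40000 nM, which corresponds to an expected step of a 1.2-fold lower number from compound 2 to compound 3 (0.08 log units; within the scatter).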

Compound 3, half-maximal inhibitory concentration: 113000 nM
Estimate against measurement, compound 3: 10-fold (1.01 log units) below; measured number above the stated range.
By their numbers in this assay, from the lowest: compounds 1 and 2 (each within the scatter of the next); then compound 3.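

In this assay, the group on the amide-type nitrogen proves able to shift the result: exchanging one halogen for another had left the number within the scatter, but 2-methylphenyl in place of 3-chloro-4-fluorophenyl gives an 8.5-fold higher number from compound 2 to compound 3 (0.93 log units; beyond the scatter). Putting 2-methylphenyl in place of 3,4-difluorophenyl gives a step of the same kind, a 12-fold higher number from compound 1 to compound 3 (1.07 log units; beyond the scatter), so the two halogenated compounds sit together on the stronger side and compound 3 lies beyond the scatter from both. No measurement available here accounts for this difference.

The change removes the halogens and adds the methyl group in a single step, so the compounds shown cannot separate what the departure of the halogens contributes from what the arrival of the methyl group contributes. On these data alone, it also remains open whether a plain phenyl group, or a phenyl ring carrying a methoxy group or a nitrile, would give a number close to those of compound 1 and compound 2 or one closer to that of compound 3.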